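The compounds below may be only part of what the source reports. "The series", "measured", "known", "first", "only" and "open" are said of these compounds alone.

Compound 2 `COc1cccc([C@H]2O[C@H](CC(=O)N[C@H](C)C(=O)O)C(=O)N(CC(C)(C)CO)c3ccc(Cl)cc32)c1OC` gives 31% in a functional assay on the whole organism for inhibition, with Rattus norvegicus as the target, at a dose of 10 mg/kg by the oral route (a lower number here means less inhibition, a higher number more inhibition at the dose given (going by the name of the read-out)), the higher of the two measured numbers, while compound 1 `COc1cccc([C@H]2O[C@H](CC(=O)N(C)CC(=O)O)C(=O)N(CC(C)(C)CO)c3ccc(Cl)cc32)c1OC` gives -1%. Compound 3 `COc1cccc([C@H]2O[C@H](CC(=O)N3CCC(CCC(=O)O)CC3)C(=O)N(CC(C)(C)CO)c3ccc(Cl)cc32)c1OC` differs from compound 2 by 4-(2-carboxyethyl)piperidin-1-yl in place of (1-carboxyethyl)amino on a carbonyl carbon. Within the data shown here, the only measured step, a number 32 percentage points higher from compound 1 to compound 2 (beyond the scatter), also changed the group on this carbonyl carbon and shows that this part of the molecule can shift the read-out strongly. Among the measured compounds shown here, no measured step matches the present change, so its direction is uncertain, although a step of comparable size either way seems possible. Compound 3 is therefore estimated at 20% (range -10% to 50%), an expected step of a number 11 percentage points lower from compound 2 to compound 3 (beyond the scatter).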

Compound 3, a percentage reported as inhibition, in the whole organism at one dose (the size of the read-out at that dose, not a potency): 76%
Compound 3: middle estimate off by 56 percentage points, on the low side; measured number above the stated range.
By their numbers in this assay, from the lowest: compound 1; then compound 2; then compound 3.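

In this assay, 4-(2-carboxyethyl)piperidin-1-yl on this carbonyl carbon gives a number 45 percentage points higher from compound 2 to compound 3 (beyond the scatter) and, against the other earlier group, a number 77 percentage points higher from compound 1 to compound 3 (beyond the scatter) as well. This group therefore reaches well beyond what the first pair showed. Like compound 1, compound 3 lacks the amide hydrogen of compound 2, so the absence of that hydrogen does not by itself bring a low number.

On these data alone, whether a longer chain on the six-membered ring, or a methyl ester in place of the carboxylic acid, would keep this number stays open. No measurement given here explains the rise.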